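The compounds below may be only part of what the source reports. "The series", "measured", "known", "first", "only" and "open" are said of these compounds alone.

Compound 1 `C=CC1=C(C(=O)NC2CCCCC2)C(c2ccc(OC)cc2)OC1` carries a cyclohexyl group on its amide-type nitrogen. In a functional assay on SW480 cells (Homo sapiens) for cytotoxicity, read by MTT assay, with a stated time of 24 h (a higher number here means a weaker inhibitor, a lower number a stronger inhibitor), compound 1 gives > 100000 nM, which is a limit of the assay rather than a measured number. Two relatives were also tested. Compound 3 `C=CC1=C(C(=O)NC2CCCCC2)C(c2ccc(F)cc2)OC1` differs from compound 1 by fluoro in place of methoxy on an aromatic carbon, and in this assay compound 3 gives > 100000 nM, again a limit. Compound 2 `C=CC1=C(C(=O)Nc2ccc(C)cc2)C(c2ccc(F)cc2)OC1` carries 4-methylphenyl on the amide-type nitrogen, and in this assay compound 2 gives > 100000 nM, also a limit. Because the limit of > 100000 nM in this assay, at which 3 of the 3 values shown sit, holds all three values, the step that the two limits leave unreadable from compound 1 to compound 3 and the step that the two limits leave unreadable from compound 2 to compound 3 cannot be given a size. Compound 4 `C=CC1=C(C(=O)NCC(C)C)C(c2ccc(OC)cc2)OC1` is the unmeasured compound; its change from compound 1 is isobutyl in place of cyclohexyl on an amide-type nitrogen. Among the measured compounds shown here, the only measured step that touches the same amide-type nitrogen, a step that the two limits leave unreadable from compound 2 to compound 3, gave no readable size, so neither a direction nor a magnitude can be drawn from it. Compound 4 is therefore expected to sit at the limit as well, the estimate being 100000 nM with a range from 50000 nM to 200000 nM, which means an expected step of a number no higher from compound 1 to compound 4 (the limit leaves the size open).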

Compound 4, half-maximal inhibitory concentration: > 100000 nM
Compound 4: a limit, no number; the forecaster's own chance of this, stated with the estimate: 85%; the middle value lies on the limit itself.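

Among the compounds shown here, compound 4 and compound 1 both give only a limit, so swapping cyclohexyl for isobutyl yields no step that can be read: the limit of > 100000 nM in this assay, at which 4 of the 4 values shown sit. The compounds shown leave open which change to the shared core, if any, would give a measurable value in this assay.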